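Chlorophenyl Position Shift in a Pyridine Triaryl Series

This account rests on a few compounds, and the source may have more. Where it says the series, first, only, none or still open, it means among the compounds named here.

Measured so far:
compound 1 `Oc1ccc(-c2cc(-c3ccc(Cl)cc3)nc(-c3cccnc3)c2)cc1`, 29300 nM
compound 2 `Oc1cccc(-c2cc(-c3ccc(Cl)cc3)nc(-c3ccsc3)c2)c1`, 11500 nM
compound 3 `Oc1ccc(-c2cc(-c3cccnc3)nc(-c3cccc(Cl)c3)c2)cc1`, 25700 nM

In a functional assay on T47D cells (Homo sapiens) for cytotoxicity, read by CCK-8 assay and cell counting, with a stated time of 2 days (on this read-out lower numbers stand for stronger inhibition and higher numbers for weaker inhibition), compound 2 gives the lowest number of the three. Compound 3 differs from compound 1 by 3-chlorophenyl in place of 4-chlorophenyl on an aromatic carbon, and this step gave a 1.1-fold lower number from compound 1 to compound 3 (0.06 log units; within the scatter). How the core of compound 2 differs from that of compound 1 is not broken down here. Compound 4 `Oc1cccc(-c2cc(-c3ccsc3)nc(-c3cccc(Cl)c3)c2)c1` is not yet measured; it differs from compound 2 by 3-chlorophenyl in place of 4-chlorophenyl on an aromatic carbon. The surroundings are not identical, since in compound 4 the site is meta to a 3-hydroxyphenyl group and a thiophen-3-yl group rather than a 4-hydroxyphenyl group and a pyridin-3-yl group, so this is the same kind of change, not the same change. Compound 4 is expected to show a 1.1-fold lower number from compound 2 to compound 4 (0.04 log units; within the scatter), resting on compound 3 having given a 1.1-fold lower number from compound 1 to compound 3 (0.06 log units; within the scatter). The estimate for compound 4 in this assay is 10500 nM, between 5000 nM and 24000 nM.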

Compound 4, half-maximal inhibitory concentration: 3540 nM
Compound 4: middle estimate off by 3.0-fold (0.47 log units), on the high side; measured number outside the range, below it.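

In this assay, putting 3-chlorophenyl in place of 4-chlorophenyl gave a 3.2-fold lower number from compound 2 to compound 4 (0.51 log units; beyond the scatter), so the change did not carry over with the same size from one core to the other: the same change on two cores in this assay, a 1.1-fold lower number (0.06 log units; within the scatter) from compound 1 to compound 3 and a 3.2-fold lower number (0.51 log units; beyond the scatter) from compound 2 to compound 4, 2.8-fold (0.45 log units) apart, beyond the scatter of two such steps

A lower number on the core of compound 2 therefore cannot be assumed for this change on another core in the series. Two pairs do not show whether the hydroxyphenyl group, the thiophen-3-yl group in place of pyridin-3-yl, or both together set the size of the step, and they offer no reason for the gap.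

Still open, going by these compounds, is how the step behaves when 3-hydroxyphenyl is paired with pyridin-3-yl, or 4-hydroxyphenyl with thiophen-3-yl. Also open, on these data alone, is what a methoxy or nitrile group would give in place of the chlorine.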